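The source may report more compounds than this note shows. Statements on the series, on what has been measured and on what is new or still open speak of the compounds shown alone.

In a functional assay on MDA-MB-231 cells (Homo sapiens) for cytotoxicity, read by MTT assay, with a stated time of 48 h (a higher number here means a weaker inhibitor, a lower number a stronger inhibitor), compound 1 `O=c1ccoc2cc(OCc3cn(Cc4ccc([N+](=O)[O-])cc4)nn3)ccc12` gives 71300 nM. That is the only plain number shown; the one other value is a limit of the test rather than a measurement. Compound 2 `O=c1ccoc2cc(OCc3cn(Cc4ccc(F)cc4)nn3)ccc12` is reported in this assay only as the limit > 100000 nM. The step of an at least 1.4-fold higher number from compound 1 to compound 2 (0.14 log units; that floor lies within the scatter) is therefore a floor rather than a measured size, and that floor lies within the usual scatter of repeated tests. The evidence on the measured steps amounts to the limit of > 100000 nM in this assay, at which 1 of the 2 values shown sits.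

Compound 3 `N#Cc1cccc(Cn2cc(COc3ccc4c(=O)ccoc4c3)nn2)c1` has not yet been measured. It differs from compound 1 by 3-cyanophenyl in place of 4-nitrophenyl on a saturated chain carbon bound to an aromatic nitrogen. Going by the values given here, the one step that bears on it is the step from compound 1 to compound 2, which likewise took the nitro group away and pointed toward a higher number, though only as a floor within the scatter. The change to the 3-cyanophenyl group is therefore expected to move the number upward by about a 1.7-fold higher number from compound 1 to compound 3 (0.23 log units; within the scatter), with a fair chance that this assay again returns only a limit. Compound 3 is estimated to give 120000 nM, with a range from 50000 nM to 300000 nM.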

Compound 3, half-maximal inhibitory concentration: > 100000 nM
Compound 3 was reported as a limit (the forecaster's own chance of this, stated with the estimate: 55%); the middle value does not contradict the limit.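

In this assay, a second replacement of the 4-nitrophenyl group, this time by 3-cyanophenyl, again fails to give a plain number, with an at least 1.4-fold higher number from compound 1 to compound 3 (0.14 log units; that floor lies within the scatter). Going by these compounds alone, compound 1 therefore remains the only compound of the three with a measured value, although this floor is too small to show that it really differs from compound 3. Compound 2 and compound 3 are both reported as limits, so the step between them cannot be read and the 4-fluorophenyl and 3-cyanophenyl groups cannot be ranked against each other, leaving the evidence at this position narrow: the limit of > 100000 nM in this assay, at which 2 of the 3 values shown sit.

Going by these compounds, it remains open how far the true values of compound 2 and compound 3 lie from that limit, and so whether either really differs from compound 1. On these data alone, it is also open whether a different group at this position, such as a 4-aminophenyl or a 4-carboxyphenyl ring, or a longer chain carrying the ring, would give a plain number clearly lower than that of compound 1. Compound 1 gives 71300 nM.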